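The compounds below may be only part of what the source reports. "The series", "measured", "known", "first", "only" and "open" are said of these compounds alone.

Measured in an ADME assay on microsomes from liver (Mus musculus) for metabolic stability, with a stated time of 30 min; a higher number here means that more of the compound is left, a lower number that less of the compound is left:
compound 1 `CCn1c(=O)/c(=C2\Sc3cc(F)ccc3N2C)s/c1=C\c1ccccn1`, 5%
compound 2 `CCn1c(=O)/c(=C2\Sc3cc(Cl)ccc3N2C)s/c1=C\c1ccccn1`, 13%

Among the compounds with values here, compound 2 stands highest of the two numbers in this assay, and its nearest neighbour is compound 1, the only step being a number 8 percentage points higher from compound 1 to compound 2 (within the scatter), which lies within the scatter. Both compounds therefore show that little of the compound remains after the stated time.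

Compound 3 `CCn1c(=O)/c(=C2\Sc3cc(Cl)ccc3N2C)s/c1=C\c1ccncc1` differs from compound 2 by pyridin-4-yl in place of pyridin-2-yl on a double-bonded chain carbon bound to an aromatic carbon. Within the data shown here, no measured step bears on this change: the single step available, a number 8 percentage points higher from compound 1 to compound 2 (within the scatter), concerns the halogen on the aromatic carbon and not the pyridyl group, and it is itself within the scatter. Nothing in the two measured values speaks for a move beyond the scatter in either direction for this change, so the expected step is a number 1 percentage points lower from compound 2 to compound 3 (within the scatter), that is, none beyond the scatter. For compound 3 the estimate in this assay is 12%, with a range from 3% to 30%.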

Compound 3, percent of the compound remaining: 39%
The estimate for compound 3 lay 27 percentage points below the measured number; the whole stated range lies below it.
By their numbers in this assay, from the lowest: compounds 1 and 2 (each within the scatter of the next); then compound 3.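

In this assay, the place on a double-bonded chain carbon bound to an aromatic carbon responds to the change of pyridyl attachment alone: pyridin-4-yl in place of pyridin-2-yl gives a number 26 percentage points higher from compound 2 to compound 3 (beyond the scatter), although both groups have the same heavy atoms and the same counts of donors and acceptors. The halogen change, with a number 8 percentage points higher from compound 1 to compound 2 (within the scatter), did not show a step of this kind, so this pyridyl change is the only one here to move the read-out beyond the scatter. No measurement at hand accounts for this step.

As far as these compounds go, what pyridin-3-yl or a plain phenyl would give at this place remains open. Also open, from the compounds shown here alone, is whether pyridin-4-yl gives a similar step with fluoro in place of chloro on the aromatic carbon, as it appears here only with chloro.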